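Swapping benzyl for methyl(phenyl)amino on compound 2's chain

The compounds below may be only part of what the source reports. "The series", "measured", "known", "first", "only" and "open" are said of these compounds alone.

In a functional assay (aorta) with Oryctolagus cuniculus as the target (a lower number here means tighter binding, a higher number weaker binding), compound 2 `Fc1ccc(C(c2ccc(F)cc2)C2CCN(CCCCc3ccccc3)CC2)cc1` gives 2.51 nM, the lower of the two measured numbers, while compound 1 `CC(=O)Nc1ccc(OCCCN2CCC(C(c3ccc(F)cc3)c3ccc(F)cc3)CC2)cc1` gives 12.6 nM. Compound 3 `CN(CCCN1CCC(C(c2ccc(F)cc2)c2ccc(F)cc2)CC1)c1ccccc1` carries methyl(phenyl)amino in place of benzyl on a saturated chain carbon, three bonds along the chain from an amine nitrogen in a ring. Among the measured compounds shown here, the only measured change at this place is a 5.0-fold lower number from compound 1 to compound 2 (0.70 log units; beyond the scatter). For the measured compounds named here, no measured compound carries the entering group, so a modest rise in this assay, no larger than that step, is expected. The expected step is a 2.0-fold higher number from compound 2 to compound 3 (0.30 log units; within the scatter). For compound 3 the estimated value is 5 nM, with an expected range from 1.5 nM to 16 nM.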

Compound 3, dissociation constant: 2 nM
The estimate for compound 3 lay 2.5-fold (0.40 log units) above the measured number, within the range that was stated.
By their numbers in this assay, from the lowest: compounds 3 and 2 (each within the scatter of the next); then compound 1.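

In this assay the exchange of benzyl for methyl(phenyl)amino gives a 1.3-fold lower number from compound 2 to compound 3 (0.10 log units; within the scatter) and so this place on the chain takes either group with no difference that can be read. Methyl(phenyl)amino also separates from 4-acetamidophenoxy, with a 6.3-fold lower number from compound 1 to compound 3 (0.80 log units; beyond the scatter) as the second step beyond the scatter away from compound 1. No evidence bears on why these groups compare as they do.

On these data alone, it remains open whether a pyridyl ring in place of the phenyl ring would fit the same pattern. As far as these compounds go, the effect of a longer chain carrying methyl(phenyl)amino also remains open.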